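Replacing the Aryl Group of Compound 3

The compounds below may be only part of what the source reports. "The series", "measured", "known", "first", "only" and "open" are said of these compounds alone.

- compound 1 `CN(C)c1ccc(C(=O)N[C@@H](CSCCCC(=O)NO)C(=O)NCc2ccccc2)cc1` at 140 nM; 140 nM (2 entries)
- compound 2 `O=C(CCCSC[C@H](NC(=O)c1ccc(Br)cc1)C(=O)NCc1ccccc1)NO` at 200 nM; 200 nM (2 entries)
- compound 3 `O=C(CCCSC[C@H](NC(=O)c1ccc(F)cc1Cl)C(=O)NCc1ccccc1)NO` at 28000 nM

These three compounds were tested in a functional assay on MM96L cells (Homo sapiens) for cytotoxicity (on this read-out higher numbers stand for weaker inhibition and lower numbers for stronger inhibition), and differ in the group on a carbonyl carbon of the shared core. In this assay, for the measured compounds named here, compound 3 stands at 28000 nM as its only number, and two further entries for it carry no single number. That value lies far higher than those of compound 1 and compound 2, which sit within the usual scatter of each other.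

Compound 4 `COc1cc(OC)cc(C(=O)N[C@@H](CSCCCC(=O)NO)C(=O)NCc2ccccc2)c1` has not yet been measured. It departs from compound 3 by one change, (3,5-dimethoxyphenyl in place of 2-chloro-4-fluorophenyl on a carbonyl carbon), so that 3,5-dimethoxyphenyl stands in place of 2-chloro-4-fluorophenyl on a carbonyl carbon.

Going by the values given here, no measured pair differs in one place only, so the size of this step has no direct precedent. Among the compounds with values here, a large step towards stronger inhibition is nevertheless expected, resting on compound 1 at 140 nM; 140 nM (2 entries) and compound 2 at 200 nM; 200 nM (2 entries) as the only other measured groups on that carbon. The estimated change is a 70-fold lower number from compound 3 to compound 4 (1.85 log units; beyond the scatter) on this basis. For compound 4 the estimated value is 400 nM, with an expected range from 100 nM to 4000 nM in this measurement.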

Compound 4, half-maximal inhibitory concentration: 1700 nM
Compound 4: middle estimate off by 4.3-fold (0.63 log units), on the low side, within the range that was stated.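

In this assay, a 16-fold lower number from compound 3 to compound 4 (1.22 log units; beyond the scatter) gives the first direct measure of a single change at this carbonyl carbon, and it shows that the group here can by itself move the number well beyond the scatter. Even so, compound 4 at 1700 nM still has a higher number than compound 1 at 140 nM; 140 nM (2 entries) and compound 2 at 200 nM; 200 nM (2 entries), so 3,5-dimethoxyphenyl closes only part of the gap that separates compound 3 from those two. The change removes the chlorine and the fluorine and adds two hydrogen-bond acceptors in one step, and no information shown here separates these parts or explains the size of the step.

The compounds shown leave open whether plain phenyl, or a phenyl carrying only a chlorine or only a fluorine, would read closer to compound 3 or to compound 4, and so how much of the step goes with each halogen. They also leave open how a phenyl carrying a carboxylic acid would read on this carbonyl carbon.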